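Changing the aryl group on the amine of a shared core

This account rests on a few compounds, and the source may have more. Where it says the series, first, only, none or still open, it means among the compounds named here.

Compound 1 `Cc1cc(N2CCCCC2)nc(SCc2nc3ccccc3[nH]2)n1`: in a functional assay on MCF7 cells (Homo sapiens) for cytotoxicity, read by MTT assay, with a stated time of 72 h (on this read-out higher numbers stand for weaker inhibition and lower numbers for stronger inhibition), compound 1 gives > 100000 nM, which is a limit of the assay.
Compound 2 `Cc1cc(Nc2ccc(Br)cc2)nc(SCc2nc3ccccc3[nH]2)n1`: in this assay compound 2 gives 38000 nM.

Compound 2 holds the only number shown; the other value is a limit (the limit of > 100000 nM in this assay, at which 1 of the 2 values shown sits). Within the data shown here, the one measured step is an at least 2.6-fold lower number from compound 1 to compound 2 (0.42 log units; beyond the scatter), and it does not touch the exchange that leads to compound 3 `COc1ccccc1Nc1cc(C)nc(SCc2nc3ccccc3[nH]2)n1`, namely (2-methoxyphenyl in place of 4-bromophenyl on a nitrogen on an aromatic ring). Among the measured compounds shown here, with no step bearing on it, no change beyond the scatter is expected in this assay, so the expected step is a 1.1-fold higher number from compound 2 to compound 3 (0.02 log units; within the scatter). Compound 3 is therefore estimated at 40000 nM, between 15000 nM and 120000 nM.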

Compound 3, half-maximal inhibitory concentration: > 100000 nM
Compound 3: no number, only a limit; the forecaster's own chance of this, stated with the estimate: 25%; middle value at least 2.5-fold (0.39 log units) away from the limit.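

In this assay, the aryl group on this nitrogen is not interchangeable: 2-methoxyphenyl in place of 4-bromophenyl gives an at least 2.6-fold higher number from compound 2 to compound 3 (0.42 log units; beyond the scatter). An arylamino group in itself is therefore not enough to give a measurable number, and the value of compound 3 is only a limit. The step between compound 1 and compound 3 cannot be read, as both values are limits: the limit of > 100000 nM in this assay, at which 2 of the 3 values shown sit.

As far as these compounds go, what stays open is whether the bromine or its place on the ring matters. 4-Methoxyphenyl and 2-bromophenyl on the same nitrogen would separate the two.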